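The source may hold more compounds than are shown below. What is called first, only, known or untested is meant among the compounds shown, and "the series" means these compounds.

Of the compounds shown here, two have so far been measured in an assay on isolated protein for inhibition of Rap guanine nucleotide exchange factor 4 (Homo sapiens), read by fluorescence and cAMP accumulation; a higher number here means a weaker inhibitor, a lower number a stronger inhibitor. Compound 1 `Cc1ccc(C)c(CSc2nc(C(C)C)c(C#N)c(=O)[nH]2)c1` gives 12700 nM. For the measured compounds named here, compound 2 `Cc1ccc(C)c(CSc2nc(C3CCN(C)CC3)c(C#N)c(=O)[nH]2)c1` gives 127000 nM, the highest of the two numbers, and the only step that reaches it, a 10-fold higher number from compound 1 to compound 2 (1.00 log units; beyond the scatter), puts it beyond the scatter from compound 1. Compound 3 `Cc1ccc(C)c(CSc2nc(C3CCNCC3)c(C#N)c(=O)[nH]2)c1` has not yet been measured. It differs from compound 2 in one place: hydrogen in place of methyl on an amine nitrogen in a ring. Going by the values given here, no measured step covers this kind of change. Among the compounds with values here, the single step on record, a 10-fold higher number from compound 1 to compound 2 (1.00 log units; beyond the scatter), concerns a different exchange, isopropyl giving way to 1-methylpiperidin-4-yl, and it says nothing about what removing the methyl from the ring nitrogen does. With nothing that bears directly on the change, a number close to that of compound 2 is expected, with no movement beyond the scatter anticipated in either direction. The expected step is a 1.3-fold lower number from compound 2 to compound 3 (0.10 log units; within the scatter). For compound 3 in this assay a half-maximal inhibitory concentration of 100000 nM is estimated, with a range from 35000 nM to 300000 nM.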

Compound 3, half-maximal inhibitory concentration: > 300000 nM
Compound 3: no number, only a limit; the forecaster's own chance of this, stated with the estimate: 30%; middle value at least 3.0-fold (0.47 log units) from the limit.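

In this assay compound 3 has no number, only a limit: the limit of > 300000 nM in this assay, at which 1 of the 3 values shown sits.

Even read as a limit, the result shows that the methyl on the amine nitrogen in the ring is not a silent feature at this position, since hydrogen in its place gives an at least 2.3-fold higher number from compound 2 to compound 3 (0.37 log units; beyond the scatter). Before this, only the exchange of the whole group was on record, and nothing separated the ring from the methyl it carries. Against isopropyl, piperidin-4-yl gives an at least 23-fold higher number from compound 1 to compound 3 (1.37 log units; beyond the scatter), so with or without the methyl, the two piperidine compounds are both weaker inhibitors than compound 1 in this assay, and the loss of the methyl adds to that gap rather than closing it.

On these data alone, how far compound 3 really lies beyond its limit stays unknown, so the full size of both steps remains open. Also open, as far as these compounds go, is whether a larger group on the ring nitrogen, such as ethyl or acetyl, would give a lower number than methyl does, and whether a carbon ring such as cyclohexyl in this position would stay close to compound 1.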